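A few compounds are considered here, and "the series" means these few. Any claim that something is new, unique, unknown or untested is made for them only; others in the source may bear on it.

Compound 1 `O=C(Cc1csc2nc(-c3ccc(Br)cc3)cn12)N/N=C/c1ccccc1`: 16200 nM
Compound 2 `O=C(Cc1csc2nc(-c3ccc(Br)cc3)cn12)N/N=C/c1ccc(O)cc1`: 17800 nM

Both values come from a functional assay on HCT-15 cells (Homo sapiens) for inhibition, read by sulforhodamine B assay, with a stated time of 48 h; a higher number here means a weaker inhibitor of growth, a lower number a stronger inhibitor of growth. Compound 2 and compound 1, the only two measured so far, lie within the scatter of each other, so neither can be ranked above the other. The next compound, compound 3 `COc1cccc(OC)c1/C=N/NC(=O)Cc1csc2nc(-c3ccc(Br)cc3)cn12`, keeps the shared core and carries 2,6-dimethoxyphenyl in place of 4-hydroxyphenyl on a carbon with a double bond to nitrogen. Among the compounds with values here, only one measured step bears on this change: a 1.1-fold higher number from compound 1 to compound 2 (0.04 log units; within the scatter). That step also alters the same aromatic ring, and it stays within the scatter. Within the data shown here, it is thin evidence, as no compound with a 2,6-dimethoxyphenyl group has been measured yet. No step beyond the scatter is therefore expected, and the expected size is a 1.1-fold lower number from compound 2 to compound 3 (0.05 log units; within the scatter). For compound 3 the estimated value is 16000 nM, with an expected range from 6500 nM to 40000 nM.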

Compound 3, concentration for 50% growth inhibition: 7410 nM
Beside the measured number, compound 3's estimate is 2.2-fold (0.33 log units) above it; the measured number falls inside the stated range.
By their numbers in this assay, from the lowest: compound 3; then compounds 1 and 2 (each within the scatter of the next).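

Until now, the aromatic ring on the carbon with a double bond to nitrogen had seemed to make little difference, as adding a hydroxy group left the number within the scatter. In this assay, within the data shown here, 2,6-dimethoxyphenyl is the first group at this place to move the number beyond the scatter, with a 2.4-fold lower number from compound 2 to compound 3 (0.38 log units; beyond the scatter) and a 2.2-fold lower number from compound 1 to compound 3 (0.34 log units; beyond the scatter), so the two comparisons agree that this change gives a stronger inhibitor of growth, though only modestly. Nothing available here explains why this change lowers the number.

From the compounds shown here alone, it remains open whether a single methoxy group on the ring would give a similar step, or whether both groups of 2,6-dimethoxyphenyl are needed. The effect of an amine or a carboxylic acid on this ring is also unknown.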